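Changing the Amine End of a Side Chain

The source may hold more compounds than are shown below. What is called first, only, known or untested is meant among the compounds shown, and "the series" means these compounds.

In a functional assay on SH-SY5Y cells (Homo sapiens) for cytotoxicity, read by MTT assay, with a stated time of 72 h (a lower number here means a stronger inhibitor, a higher number a weaker inhibitor), compound 3 `CN1CCN(CCCn2c3c(c4ccccc42)C(=O)c2c[n+]([O-])c4ccccc4c2C3=O)CC1` gives 560 nM and compound 1 `CN(C)CCCCCn1c2c(c3ccccc31)C(=O)c1c[n+]([O-])c3ccccc3c1C2=O` gives 370 nM as its value, a pair with no real gap between them (a 1.5-fold higher number from compound 1 to compound 3 (0.18 log units; within the scatter)). Compound 2 `CN1CCN(CCCCn2c3c(c4ccccc42)C(=O)c2c[n+]([O-])c4ccccc4c2C3=O)CC1` gives 100 nM as a clearly lower number (a 3.7-fold lower number from compound 1 to compound 2 (0.57 log units; beyond the scatter)).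

Compound 4 `CN(C)CCCCn1c2c(c3ccccc31)C(=O)c1c[n+]([O-])c3ccccc3c1C2=O` differs from compound 3 in one place ((dimethylamino)methyl in place of 4-methylpiperazin-1-yl on a saturated chain carbon, three bonds along the chain from an aromatic nitrogen): (dimethylamino)methyl in place of 4-methylpiperazin-1-yl on a saturated chain carbon, three bonds along the chain from an aromatic nitrogen. The side chain thus turns from 3-(4-methylpiperazin-1-yl)propyl into 4-(dimethylamino)butyl.

Among the measured compounds shown here, no measured pair changes the end group alone. Compound 4 shares its butyl chain with compound 2, which points to a lower number (a 5.6-fold higher number from compound 2 to compound 3 (0.75 log units; beyond the scatter)). It shares its dimethylamino end with compound 1, which points to little change (a 1.5-fold higher number from compound 1 to compound 3 (0.18 log units; within the scatter)). A course between the two is expected, an estimated step of a 2.8-fold lower number from compound 3 to compound 4 (0.45 log units; beyond the scatter) in this assay with wide uncertainty. The value estimated for compound 4 is 200 nM (expected range 70 nM to 560 nM).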

Compound 4, half-maximal inhibitory concentration: 250 nM
Estimate against measurement, compound 4: 1.3-fold (0.10 log units) below; the range from low to high includes it.
By their numbers in this assay, from the lowest: compound 2; then compounds 4, 1 and 3 (each within the scatter of the next, the first and the last beyond it).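

Among the compounds shown here, compound 4 gives the first reading of the end group alone, on a shared butyl chain: a 2.5-fold higher number from compound 2 to compound 4 (0.40 log units; beyond the scatter). With the dimethylamino end kept and only the chain length changed, the two compounds show no real gap (a 1.5-fold lower number from compound 1 to compound 4 (0.17 log units; within the scatter)), whereas going from the 3-(4-methylpiperazin-1-yl)propyl side chain to 4-(dimethylamino)butyl gives a 2.2-fold lower number from compound 3 to compound 4 (0.35 log units; beyond the scatter). The piperazine swap with its shorter chain therefore has no single effect, and its direction depends on the side chain it starts from: the same change on two cores in this assay, a 3.7-fold lower number (0.57 log units; beyond the scatter) from compound 1 to compound 2 and a 2.2-fold higher number (0.35 log units; beyond the scatter) from compound 4 to compound 3, 8.3-fold (0.92 log units) apart, beyond the scatter of two such steps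

Still open, going by these compounds, is how a 3-(dimethylamino)propyl or a 5-(4-methylpiperazin-1-yl)pentyl side chain would fit this picture, which would show whether the reversal holds across chain lengths. Also open, on these data alone, is whether a different end on the butyl chain, such as morpholin-4-yl, would read closer to compound 2 or to compound 4.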